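The source may report more compounds than this note shows. Statements on the series, on what has been measured and on what is new or still open speak of the compounds shown alone.

Measured compounds:
- compound 1, `CCCCCCCCCCCCCCCCCCNC(=O)Nc1c(C)cccc1C`: 610 nM; 610 nM (2 entries) in an assay on microsomes from intestinal mucosa for inhibition of acyl-CoA:cholesterol acyltransferase (Oryctolagus cuniculus); a higher number here means a weaker inhibitor, a lower number a stronger inhibitor
- compound 2, `CCCCCCCC/C=C\CCCCCCCCNC(=O)Nc1c(C)cccc1Cl`: 180 nM in this assay

Compound 2 carries the only single number shown for it in this assay; one further entry for compound 2 gives no single number. Compound 1 and compound 2 differ in more than one place, so their two values are simply set side by side: compound 1 gives 610 nM; 610 nM (2 entries) and compound 2 gives 180 nM.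

Compound 3, `CCCCCCCCCCCCCCCCCCNC(=O)Nc1c(C)cccc1Cl`, is not yet measured. It differs from compound 2 in one place: decyl in place of dec-1-en-1-yl on a saturated chain carbon, eight bonds along the chain from an amide-type nitrogen. Going by the values given here, no measured pair shows this change alone. The saturated chain of compound 1 sits on a different core, so it offers no direct guide. The expectation is a step of a 1.4-fold higher number from compound 2 to compound 3 (0.16 log units; within the scatter), within the usual scatter or at most slightly weakening. Compound 3 is therefore estimated at 260 nM, with a range from 100 nM to 700 nM.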

Compound 3, half-maximal inhibitory concentration: 1100 nM
Estimate against measurement, compound 3: 4.2-fold (0.63 log units) below, outside the stated range (above it).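

In this assay, decyl in place of dec-1-en-1-yl on a saturated chain carbon, eight bonds along the chain from an amide-type nitrogen, gives a 6.1-fold higher number from compound 2 to compound 3 (0.79 log units; beyond the scatter) and so shows that this place in the chain is sensitive to the change. The two groups have the same count of heavy atoms, and the double bond is the only difference between them, so this single change alone separates the two compounds, which the side-by-side values of compound 1 and compound 2 could not show. Nothing available explains the size of this step.

Still open, on these data alone, is whether the same change on the core of compound 1 would give a step of like size. As far as these compounds go, it is also open whether a triple bond at this place or a longer chain would keep the value of compound 2 at 180 nM or lose it as decyl does.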